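The compounds below may be only part of what the source reports. "The series", "measured", "known", "first", "only" and "open" are said of these compounds alone.

Measured in this series:
compound 1 `CC(C)(C)c1nn2cc(Cl)ccc2c1Cc1cccc(C(=O)O)n1` — 48 nM
compound 2 `O=C(O)c1cccc(Cc2c(C3CC3)nn3cc(Cl)ccc23)n1` — 1500 nM

Among the compounds with values here, compound 2 holds the higher of the two numbers in a functional assay on cells for antagonist activity at prostaglandin E2 receptor EP1 subtype (Rattus norvegicus), read by fluorescence and calcium flux, with a stated time of 60 s; on this read-out lower numbers stand for stronger inhibition and higher numbers for weaker inhibition; the single step separating the pair is a 31-fold higher number from compound 1 to compound 2 (1.49 log units; beyond the scatter). The unmeasured compound 3 `O=C(O)c1cccc(Cc2c(N3CCCC3)nn3cc(Cl)ccc23)n1` differs from compound 2 in one place: pyrrolidin-1-yl in place of cyclopropyl on an aromatic carbon. Within the data shown here, the one measured step bears on the same position, since a 31-fold higher number from compound 1 to compound 2 (1.49 log units; beyond the scatter) also exchanges the group on that aromatic carbon, and it was large. Neither group of that step is pyrrolidin-1-yl, however, so it fixes no direction for the present change; the range must stay wide. The expectation for this assay is therefore a step of a 1.7-fold lower number from compound 2 to compound 3 (0.22 log units; within the scatter), a modest movement that may not exceed the scatter. Compound 3 is estimated at 900 nM, within 150 nM to 5000 nM.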

Compound 3, half-maximal inhibitory concentration: 1800 nM
Compound 3: middle estimate off by 2.0-fold (0.30 log units), on the low side; the range from low to high includes it.
By their numbers in this assay, from the lowest: compound 1; then compounds 2 and 3 (each within the scatter of the next).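

In this assay, a 1.2-fold higher number from compound 2 to compound 3 (0.08 log units; within the scatter) shows no separation between cyclopropyl and pyrrolidin-1-yl on this aromatic carbon, even though the entering group brings more heavy atoms, a ring nitrogen and a hydrogen-bond acceptor. Against tert-butyl, the picture stays as it was with cyclopropyl: a 38-fold higher number from compound 1 to compound 3 (1.57 log units; beyond the scatter) leaves compound 1 the strongest of the three, with two different rings on the weak side of it. The data offer no measured basis for explaining why tert-butyl stands apart from both rings.

Open, as far as these compounds go, is whether branched, non-ring groups such as isopropyl or dimethylamino at this carbon would come closer to tert-butyl than to the two rings. Also open, from the compounds shown here alone, is whether a smaller ring-bearing amine, such as azetidin-1-yl, would stay level with compound 3 or move away from it.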